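The compounds below may be only part of what the source reports. "The series", "measured", "known", "first", "only" and "open" are said of these compounds alone.

In a functional assay on KB cells (Homo sapiens) for cytotoxicity, read by resazurin assay, with a stated time of 3 days (a higher number here means a weaker inhibitor, a lower number a stronger inhibitor), three compounds have numbers so far:
- compound 1 `CCCC(C)C(=O)NCC(C)(C)CC1=C(O)C(=O)c2ccccc2C1=O` gives 47100 nM
- compound 2 `CCCCCCC(=O)NCC(C)(C)CC1=C(O)C(=O)c2ccccc2C1=O` gives 28200 nM
- compound 3 `CCCCCCC(=O)OCC(C)(C)CC1=C(O)C(=O)c2ccccc2C1=O` gives 14400 nM

Compound 3 cannot be separated from compound 2 on these numbers, but it can be separated from compound 1. The gap a 2.0-fold lower number from compound 2 to compound 3 (0.29 log units; within the scatter) lies within the scatter, while the gap a 3.3-fold lower number from compound 1 to compound 3 (0.51 log units; beyond the scatter) lies beyond it, though only modestly.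

Compound 4 `CCCCCCCCC(=O)OCC(C)(C)CC1=C(O)C(=O)c2ccccc2C1=O` differs from compound 3 by one change, (ethyl in place of hydrogen on a saturated chain carbon, six bonds along the chain from a carbonyl carbon), which can also be read as propyl to pentyl. In other words, a chain grows longer while everything else stays the same.

Going by the values given here, no measured step makes this exact change, so the evidence is indirect. The closest is a 1.7-fold lower number from compound 1 to compound 2 (0.22 log units; within the scatter), which alters only the chain on the carbonyl carbon, by swapping 1-methylbutyl for hexyl, and it stayed within the scatter. The other two steps replace the link to the chain, so they say little about chain length.

In this assay the expected result is a 1.2-fold lower number from compound 3 to compound 4 (0.08 log units; within the scatter) and thus no step beyond the scatter. The estimate for compound 4 is 12000 nM, with an expected range from 5000 nM to 28000 nM as the likely outcome.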

Compound 4, half-maximal inhibitory concentration: 38700 nM
Estimate against measurement, compound 4: 3.2-fold (0.51 log units) below; the measured number lies above the stated range.
By their numbers in this assay, from the lowest: compounds 3, 2, 4 and 1 (each within the scatter of the next, the first and the last beyond it).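

Making the chain longer, read as propyl to pentyl, has a readable effect at this position: in this assay it gives a 2.7-fold higher number from compound 3 to compound 4 (0.43 log units; beyond the scatter), so the extra ethyl moves compound 4 towards a weaker inhibitor, though only modestly. Going by these compounds alone, the earlier compounds could not show this, since the one earlier step that altered only the chain, a 1.7-fold lower number from compound 1 to compound 2 (0.22 log units; within the scatter), swapped 1-methylbutyl for hexyl and stayed within the scatter. Nothing measured alongside these numbers bears on why the number rose.

On these data alone, a single step of this kind is not yet a trend, so it remains open whether a still longer chain would raise the number further, or whether a shorter chain on the same carbonyl carbon would lower it. Also open, as far as these compounds go, are whether the same lengthening would have a similar effect with the amide link of compound 2, and how a chain carrying an amine or a carboxylic acid would behave in this position.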